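The source may hold more compounds than are shown below. What is called first, only, known or untested is meant among the compounds shown, and "the series" means these compounds.

Measured so far: compound 2 `NC1=NC2(CCOCC2)N(OCCCOc2ccc(Cl)cc2)C(N)=N1` gives 360 nM; compound 1 `NC1=NC2(CCSCC2)N(OCCCOc2ccc(Cl)c(Cl)c2)C(N)=N1` gives 1 nM; compound 3 `NC1=NC2(CCSCC2)N(OCCCOc2ccccc2Br)C(N)=N1` gives 40 nM.

In a functional assay on A549 cells (Homo sapiens) for antiproliferative activity, read by MTT assay, with a stated time of 72 h (a lower number here means a stronger inhibitor, a higher number a weaker inhibitor), compound 2 stands highest of the three numbers, beyond the scatter from both compound 3 and compound 1. Compound 4 `NC1=NC2(CCOCC2)N(OCCCOc2cccc(Br)c2)C(N)=N1` differs from compound 2 by 3-bromophenyl in place of 4-chlorophenyl on an oxygen on a saturated carbon. For the measured compounds named here, no measured step covers this exact change; the only step on the aryl group, a 40-fold higher number from compound 1 to compound 3 (1.60 log units; beyond the scatter), sits on the core of compound 1 and swaps different halogen patterns, so it shows only that such changes can be large in either direction. Compound 4 is therefore expected to sit close to compound 2, with a wide range, giving an estimated 1.2-fold lower number from compound 2 to compound 4 (0.08 log units; within the scatter). Compound 4 is estimated at 300 nM, within 50 nM to 1800 nM.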

Compound 4, half-maximal inhibitory concentration: 160 nM
Compound 4: middle estimate off by 1.9-fold (0.27 log units), on the high side, within the range that was stated.
By their numbers in this assay, from the lowest: compound 1; then compound 3; then compound 4; then compound 2.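

On the core of compound 2 in this assay, 3-bromophenyl in place of 4-chlorophenyl gives a 2.3-fold lower number from compound 2 to compound 4 (0.35 log units; beyond the scatter), a modest step just beyond the scatter. For the compounds shown here, the only other aryl step, a 40-fold higher number from compound 1 to compound 3 (1.60 log units; beyond the scatter), is larger and sits on the core of compound 1, so this result shows that the aryl group also moves the number on this second core. No measured evidence bears on the reason for this step.

Going by these compounds, because the halogen and its place change together, their separate contributions remain open. Also open, on these data alone, is how an amine or a carboxylic acid on the phenyl ring would read.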